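The source may hold more compounds than are shown below. What is called first, only, known or untested is meant among the compounds shown, and "the series" means these compounds.

Values so far in a functional assay on NCI-H460 cells (Homo sapiens) for antiproliferative activity, read by MTT assay, with a stated time of 48 h (on this read-out higher numbers stand for weaker inhibition and lower numbers for stronger inhibition), for the series
- Compound 1 `COc1cc(-c2cccc3nc(-c4ccc(Br)cc4)oc23)cc(OC)c1OC` gives > 25000 nM as a limit
- Compound 2 `COc1cc(-c2cccc3nc(-c4ccc(Cl)cc4)oc23)cc(OC)c1OC` gives > 25000 nM as a limit
- Compound 3 `COc1cc(-c2cccc3nc(-c4cccc(O)c4)oc23)cc(OC)c1OC` is not yet measured

Compound 2 stands only as a limit, with > 25000 nM as its entry and no number behind it. Going by the values given here, the measured set holds no readable number so far (the limit of > 25000 nM in this assay, at which 2 of the 2 values shown sit). Compound 3 carries 3-hydroxyphenyl in place of 4-chlorophenyl on an aromatic carbon of the five-membered aromatic ring, next to the ring nitrogen and next to the ring oxygen (3-hydroxyphenyl in place of 4-chlorophenyl on an aromatic carbon). Among the compounds with values here, the one measured step at this group is a step that the two limits leave unreadable from compound 1 to compound 2 with chloro in place of bromo on an aromatic carbon, so it supplies no size to carry over. Within the data shown here, no step of known size can therefore be expected in this assay, and the only direction open to a readable result is toward stronger inhibition. The estimated step is an at least 1.2-fold lower number from compound 2 to compound 3 (0.09 log units; that floor lies within the scatter) and it remains a loose expectation. Another limit is expected about as often as a number. For compound 3 the expected value is 20000 nM with an estimated range of 3000 nM to 50000 nM for this measurement.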

Compound 3, half-maximal inhibitory concentration: 1900 nM
For compound 3 the middle estimate is 11-fold (1.02 log units) above the measured one, outside the stated range (below it).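

In this assay, going by these compounds alone, the aromatic carbon of the five-membered ring, next to the ring nitrogen and next to the ring oxygen, is the first place where a change yields a readable number: 3-hydroxyphenyl in place of 4-chlorophenyl gives an at least 13-fold lower number from compound 2 to compound 3 (1.11 log units; beyond the scatter), and 3-hydroxyphenyl in place of 4-bromophenyl gives an at least 13-fold lower number from compound 1 to compound 3 (1.11 log units; beyond the scatter). Both steps are floors rather than sizes, and the step between the two halogen compounds cannot be read, since compound 1 and compound 2 each stand only as a limit: the limit of > 25000 nM in this assay, at which 2 of the 3 values shown sit. Activity at this place is therefore not closed off by the shared core, and the aryl group here can decide between a limit and a number.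

The change moves the substituent on the phenyl ring as well as replacing it, so the compounds shown do not tell whether the hydroxyl group or its 3-position carries the step. 4-Hydroxyphenyl, 3-chlorophenyl, 3-methoxyphenyl and 3-aminophenyl at this place would separate those two factors, and an unsubstituted phenyl would give a reference for all of them.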